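A few compounds are considered here, and "the series" means these few. Any claim that something is new, unique, unknown or untested is made for them only; others in the source may bear on it.

Two compounds have numbers in a functional assay for antagonist activity at Alpha-1A adrenergic receptor (Oryctolagus cuniculus); on this read-out lower numbers stand for tighter binding and higher numbers for weaker binding. Compound 1 `Cc1cnccc1N1CCN(CCCNc2ncccc2C(=O)N(C)C)CC1` gives 200 nM. Compound 2 `CN(C)C(=O)c1cccnc1NCCCN1CCN(c2ccccc2Cc2ccccc2)CC1` gives 6.31 nM, the lowest of the two, with compound 1 the nearest and its gap to compound 2 beyond the scatter. Compound 3 `CN(C)C(=O)c1cccnc1NCCCN1CCN(c2ccccc2C2CC2)CC1` has not yet been measured in this assay. It differs from compound 2 in one place: cyclopropyl in place of benzyl on an aromatic carbon. Within the data shown here, no step between measured compounds of this kind is available, so the expectation rests on the change itself. The step of a 4.0-fold higher number from compound 2 to compound 3 (0.60 log units; beyond the scatter) is expected to be a moderate rise, beyond the scatter. Compound 3 is estimated at 25 nM, within a range from 6 nM to 100 nM.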

Compound 3, dissociation constant: 0.631 nM
Compound 3: the middle estimate sits 40-fold (1.60 log units) above what was measured; the whole stated range lies above it.
By their numbers in this assay, from the lowest: compound 3; then compound 2; then compound 1.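

In this assay, on an aromatic carbon ortho to a large group, replacing benzyl with cyclopropyl gives a 10-fold lower number from compound 2 to compound 3 (1.00 log units; beyond the scatter). A six-membered aromatic ring at this position is therefore not required for a low number, and a group of 3 heavy atoms does better here than one of 7. Replacing 3-methylpyridin-4-yl with 2-cyclopropylphenyl on the amine nitrogen in a ring gives a 320-fold lower number from compound 1 to compound 3 (2.50 log units; beyond the scatter), a large step.

As far as these compounds go, whether methyl, isopropyl or cyclobutyl at this position would give a lower or higher number stays open. Nothing available here accounts for the size of these steps.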